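Swapping the Chlorophenyl of Compound 1 for a Fluorophenyl

The source may hold more compounds than are shown below. What is called first, only, known or untested is meant among the compounds shown, and "the series" means these compounds.

Among the measured compounds shown here, compound 1, `O=C(COc1ccc(C(=O)/C=C/c2ccccc2Cl)cc1)N[C@H]1CCOC1=O`, is the only member of this set with a number in a functional assay on MCF7 cells (Homo sapiens) for antiproliferative activity, read by MTT assay, with a stated time of 72 h; a higher number here means a weaker inhibitor, a lower number a stronger inhibitor: compound 1 gives 17400 nM. Compound 2, `O=C(CNc1ccccc1)N[C@H]1CCOC1=O`, reaches only the limit of the assay in this assay, > 64000 nM. Compound 3, `O=C(CNc1ccccc1F)N[C@H]1CCOC1=O`, likewise stops at the limit in this assay, > 64000 nM. For the measured compounds named here, the single measured step, a step that the two limits leave unreadable from compound 2 to compound 3, cannot be read, since the limit of > 64000 nM in this assay, at which 2 of the 3 values shown sit, hides whatever the fluoro brought. Compound 4, `O=C(COc1ccc(C(=O)/C=C/c2ccc(F)cc2)cc1)N[C@H]1CCOC1=O`, differs from compound 1 in one place: 4-fluorophenyl in place of 2-chlorophenyl on a double-bonded chain carbon bound to a double-bonded chain carbon. Going by the values given here, no readable measured step bears on this change, and the one unreadable step sits on a different core, so the number for compound 4 rests on compound 1 alone. The step is expected to stay within the usual scatter, with a 1.0-fold lower number from compound 1 to compound 4 (0.01 log units; within the scatter) expected to be close to nothing. Compound 4 is therefore estimated at 17000 nM in this assay, with an expected range from 6000 nM to 48000 nM.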

Compound 4, half-maximal inhibitory concentration: > 64000 nM
Compound 4: no number, only a limit; the forecaster's own chance of this, stated with the estimate: 15%; at least 3.7-fold (0.57 log units) between middle value and limit.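

In this assay, among the compounds shown here, replacing 2-chlorophenyl with 4-fluorophenyl gives an at least 3.6-fold higher number from compound 1 to compound 4 (0.56 log units; beyond the scatter), the first readable step in this set, as the only earlier step could not be read. Compound 4 gives > 64000 nM as a limit of the assay and not a number, so this step marks only a minimum size. The result shows that the aryl group at this place on the chain of the core of compound 1 cannot be exchanged freely, but the full size of the change stays hidden because of this: the limit of > 64000 nM in this assay, at which 3 of the 4 values shown sit.

The change alters the halogen and its place on the phenyl ring together, so the two cannot be separated here. Going by these compounds, whether a 4-chlorophenyl or a 2-fluorophenyl group would stay with compound 1 or with compound 4 remains open.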